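Methyl on the fused five-membered ring: compound 3 to compound 4

The source may report more compounds than this note shows. Statements on the series, on what has been measured and on what is new or still open speak of the compounds shown alone.

In a functional assay on HeLa cells (Homo sapiens) for antiproliferative activity (a higher number here means a weaker inhibitor, a lower number a stronger inhibitor), compound 3 `CO/N=C/c1c(N)ncnc1Oc1ccc2[nH]ccc2c1` gives 1870 nM, the highest number of the three measured. Compound 1 `CCO/N=C/c1c(N)ncnc1Oc1ccc2[nH]c(C)cc2c1F` gives 32 nM and compound 2 `COCCO/N=C/c1c(N)ncnc1Oc1ccc2[nH]c(C)cc2c1F` gives 308 nM; both of these numbers lie below that of compound 3 by more than the scatter. Going by the values given here, the only single-point step among the measured compounds is a 9.6-fold higher number from compound 1 to compound 2 (0.98 log units; beyond the scatter), and it concerns the saturated chain on the oxygen, not the fused ring system.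

Compound 4 `CO/N=C/c1c(N)ncnc1Oc1ccc2[nH]cc(C)c2c1` differs from compound 3 by methyl in place of hydrogen on an aromatic carbon. Among the compounds with values here, no measured step touches an aromatic carbon of the five-membered ring, so the step of a 9.6-fold higher number from compound 1 to compound 2 (0.98 log units; beyond the scatter) offers no direct guide; compounds 1 and 2 carry a methyl on that ring together with several other differences from compound 3, so their values cannot be read as a single change. The expectation for compound 4 is therefore a step of a 1.6-fold lower number from compound 3 to compound 4 (0.19 log units; within the scatter), a small change whose direction is uncertain and that may well stay within the scatter. Compound 4 is estimated at 1200 nM, with a range from 400 nM to 3600 nM.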

Compound 4, half-maximal inhibitory concentration: 306 nM
Compound 4: middle estimate off by 3.9-fold (0.59 log units), on the high side; measured number outside the range, below it.
By their numbers in this assay, from the lowest: compound 1; then compounds 4 and 2 (each within the scatter of the next); then compound 3.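

In this assay the step of a 6.1-fold lower number from compound 3 to compound 4 (0.79 log units; beyond the scatter) comes from methyl in place of hydrogen on an aromatic carbon of the five-membered aromatic ring, two ring bonds from the ring nitrogen. Going by these compounds alone, this is the only single-place reading at this ring so far, and it shows that this position responds to one added carbon: the change lies beyond the scatter and goes towards the lower number. No measured evidence bears on why this methyl has this effect.

The compounds shown leave open whether an ethyl, a chlorine or a hydroxymethyl on the same carbon would keep, extend or lose the lower number. Also open, on these data alone, is whether the methyl step stays the same size when the chain on the oxygen is longer than in compound 3.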